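From Benzylamino to Dimethylamino on the Shared Core

A few compounds are considered here, and "the series" means these few. Any claim that something is new, unique, unknown or untested is made for them only; others in the source may bear on it.

Of the compounds shown here, three have so far been tested in a functional assay (Homo sapiens) for inhibition of Nucleic Acid, tested at 100 uM; on this read-out lower numbers stand for less inhibition and higher numbers for more inhibition at the one concentration tested (going by the name of the read-out). Compound 1 `CSc1[nH]ccc2ncnc1-2` gives 4%, and compound 2 `[O-][n+]1ccc2[nH]cnc2c1` gives 3%; both numbers are low. Compound 3 `OC[C@H]1O[C@@H](n2cnc3c(NCc4ccccc4)nccc32)C[C@@H]1O` gives 15%, the highest of the three, beyond the scatter relative to compound 1 and to compound 2. Compound 4 `CN(C)c1nccc2c1ncn2[C@H]1C[C@H](O)[C@@H](CO)O1` has not yet been measured. It differs from compound 3 in one place: dimethylamino in place of benzylamino on an aromatic carbon. For the measured compounds named here, no measured pair shows a step of this kind, so the expectation has little to lean on. Going by the values given here, every number so far is small, and the step of a number 7 percentage points lower from compound 3 to compound 4 (within the scatter) is expected to be small as well, most likely a slight fall or nothing beyond the scatter. Compound 4 is therefore estimated at 8%, within a range from 0% to 20%.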

Compound 4, a percentage reported as inhibition, at one concentration (the size of the read-out at that concentration, not a potency): 0%
Estimate against measurement, compound 4: 8 percentage points above; the range from low to high includes it.
By their numbers in this assay, from the lowest: compounds 4, 2 and 1 (each within the scatter of the next); then compound 3.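

For the compounds shown here, on this aromatic carbon next to the ring nitrogen, putting dimethylamino in place of benzylamino gives the first readable step in this assay, a number 15 percentage points lower from compound 3 to compound 4 (beyond the scatter) and beyond the usual scatter. The read-out therefore responds to what sits at this position, and on the shared core the small inhibition appears with benzylamino and not with dimethylamino. Nothing available explains the fall. Still open, going by these compounds, is whether the aromatic ring of benzylamino or the hydrogen on its nitrogen matters more, and how a methylamino group or a longer chain such as phenylethylamino would fare at this carbon.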